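A few compounds are considered here, and "the series" means these few. Any claim that something is new, unique, unknown or untested is made for them only; others in the source may bear on it.

Compound 1 `COc1cccc(/C=C2\CCC/C(=C\c3cccc(OC)c3OC)C2=O)c1` and compound 2 `COc1cc(/C=C2\CCC/C(=C\c3cccc(OC)c3OC)C2=O)cc(OC)c1` share one core, and compound 2 carries one methoxy more. In a functional assay on SW-620 cells (Homo sapiens) for cytotoxicity, read by MTT assay, with a stated time of 72 h (on this read-out lower numbers stand for stronger inhibition and higher numbers for weaker inhibition), compound 1 gives 7000 nM, while compound 2 gives 3800 nM. The change between them is methoxy in place of hydrogen on an aromatic carbon, and the step it made is a 1.8-fold lower number from compound 1 to compound 2 (0.27 log units; within the scatter). Compound 3 `COc1ccc(/C=C2\CCC/C(=C\c3ccc(OC)c(OC)c3)C2=O)cc1` holds the same atoms as compound 1 joined differently; the difference between the two cores is not broken down here. In this assay compound 3 gives 6600 nM. Compound 4 `COc1ccc(/C=C2\CCC/C(=C\c3ccc(OC)c(OC)c3)C2=O)cc1OC` awaits measurement. It differs from compound 3 by methoxy in place of hydrogen on an aromatic carbon, the same kind of change as before, though here the place is ortho to a methoxy group and meta to a large group, rather than meta to a large group and meta to a methoxy group. The expected step from compound 3 to compound 4 in this assay is a 1.5-fold lower number from compound 3 to compound 4 (0.17 log units; within the scatter), resting on the earlier step of a 1.8-fold lower number from compound 1 to compound 2 (0.27 log units; within the scatter). Compound 4 is therefore expected to give about 4500 nM, estimated to lie between 2500 nM and 9000 nM.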

Compound 4, half-maximal inhibitory concentration: 4500 nM
The estimate for compound 4 equals the measured number at the digits printed; low and high end bracket the measured number.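

In this assay, methoxy in place of hydrogen on an aromatic carbon gives a 1.5-fold lower number from compound 3 to compound 4 (0.17 log units; within the scatter) as its step. The two steps for this change agree: the same change on two cores in this assay, a 1.8-fold lower number (0.27 log units; within the scatter) from compound 1 to compound 2 and a 1.5-fold lower number (0.17 log units; within the scatter) from compound 3 to compound 4, 1.3-fold (0.10 log units) apart, within the scatter of two such steps. So the change carries over between these two cores without a detectable difference, but each step lies within the scatter, which means neither shows that the added methoxy has a real effect, and two pairs set no rule for the series.

Every group added here is a methoxy, so the compounds shown leave open what an amine, a carboxylic acid or a longer chain would do at the same place. Going by these compounds, whether any such group would give a step beyond the scatter also remains unknown.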